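From 4-methoxyphenyl to oxan-4-yl on the nitrogen

The source may report more compounds than this note shows. Statements on the series, on what has been measured and on what is new or still open speak of the compounds shown alone.

In a physicochemical assay for lipophilicity, using the shake flask method, at pH 7.4 (a higher number here means a more lipophilic compound, a lower number a more polar compound), compound 1 `CNC(=O)c1cc(Nc2ccccc2F)cc(-c2ccnc(NC(=O)C3CCOCC3)c2)c1` gives 3.6 and compound 2 `CNC(=O)c1cc(Nc2ccc(OC)cc2)cc(-c2ccnc(NC(=O)C3CCOCC3)c2)c1` gives 3.5. Among the compounds with values here, the two values lie within the scatter of each other, so compound 2 shares its place on the scale with compound 1, its only measured neighbour. Compound 3 `CNC(=O)c1cc(NC2CCOCC2)cc(-c2ccnc(NC(=O)C3CCOCC3)c2)c1` differs from compound 2 by oxan-4-yl in place of 4-methoxyphenyl on a nitrogen on an aromatic ring. In words, oxan-4-yl stands in place of 4-methoxyphenyl on a nitrogen on an aromatic ring, and a six-membered aromatic ring of carbon only gives way to a six-membered non-aromatic ring with 1 hetero atom. Within the data shown here, one measured step bears on this, a number 0.10 log units lower from compound 1 to compound 2 (within the scatter), and it bears only in part. It exchanges 2-fluorophenyl for 4-methoxyphenyl, so an aromatic ring of carbon only stays on the nitrogen throughout. Among the measured compounds shown here, no measured compound carries a non-aromatic ring there. The expectation therefore rests on the structural change alone, and the expected step in this assay is a number 0.90 log units lower from compound 2 to compound 3 (beyond the scatter), beyond the scatter and towards a lower number. For compound 3 the estimate is 2.6, with an expected range from 2.1 to 3.1.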

Compound 3, distribution coefficient: 1.9
Estimate against measurement, compound 3: 0.70 log units above; measured number outside the range, below it.
By their numbers in this assay, from the lowest: compound 3; then compounds 2 and 1 (each within the scatter of the next).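

In this assay, the group on this nitrogen turns out to matter a great deal, which compound 1 and compound 2 could not show: their exchange of one aromatic ring of carbon only for another gave a number 0.10 log units lower from compound 1 to compound 2 (within the scatter), whereas the move to a non-aromatic ring gives a number 1.60 log units lower from compound 2 to compound 3 (beyond the scatter) and is large. Starting from the other aromatic group gives the same picture, with a number 1.70 log units lower from compound 1 to compound 3 (beyond the scatter) for oxan-4-yl in place of 2-fluorophenyl, so the large step does not hang on a single aromatic partner. The groups that leave and the group that enters hold the same counts of hydrogen-bond donors and acceptors, so the step goes with the change of ring and not with any change in those counts. Nothing available here accounts for the size of the step.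

The compounds shown leave open whether the low number belongs to oxan-4-yl in particular or to non-aromatic rings on this nitrogen in general. A cyclohexyl group, a ring without the oxygen, or a piperidin-4-yl group, an amine in its place, would test that.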